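The source may hold more compounds than are shown below. What is called first, only, known or untested is meant among the compounds shown, and "the series" means these compounds.

Measured compounds:
- compound 1 `CC1(C)CCOc2ccc(NC(=O)Nc3ccc([N+](=O)[O-])cc3)cc21`: in a functional assay on A2780 cells (Homo sapiens) for inhibition, with a stated time of 72 h, tested at 10 uM (a higher number here means more inhibition of growth at the concentration tested, a lower number less inhibition of growth), compound 1 gives 74%
- compound 2 `CC1(C)CC(C)(C)c2cc(NC(=S)Nc3ccc(S(N)(=O)=O)cc3)ccc2O1`: compound 2 gives 32%
- compound 3 `CC1(C)CC(C)(C)c2cc(NC(=O)Nc3ccc(C(F)(F)F)cc3)ccc2O1`: compound 3 gives 88.4%

Compound 2 stands lowest of the three numbers in this assay; the gap to compound 1 and the larger gap to compound 3 both lie beyond the scatter. Compound 4 `CC1(C)CC(C)(C)c2cc(NC(=S)Nc3ccc(C(F)(F)F)cc3)ccc2O1` is not yet measured in this assay. It differs from compound 2 in one place: trifluoromethyl in place of sulfamoyl on an aromatic carbon. Going by the values given here, no pair of measured compounds differs in only one place, so no step of this kind has been seen directly. Compound 3 carries the same trifluoromethyl on the same ring, but with a carbonyl in place of the thiocarbonyl, and compound 3 gives 88.4%; this is the nearest point of reference. The expectation is a step upward from compound 2 to compound 4 of a number 38 percentage points higher from compound 2 to compound 4 (beyond the scatter), well beyond the scatter, since compound 3 with the same trifluoromethyl shows 88.4%. Compound 4 is estimated at 70%, with a range from 45% to 92%.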

Compound 4, percent growth inhibition at one concentration: 2%
The estimate for compound 4 lay 68 percentage points above the measured number, and the stated range ends above it.
By their numbers in this assay, from the lowest: compound 4; then compound 2; then compound 1; then compound 3.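

In this assay, trifluoromethyl in place of sulfamoyl on an aromatic carbon, para to a large group, gives a number 30 percentage points lower from compound 2 to compound 4 (beyond the scatter), so among these thiocarbonyl compounds sulfamoyl is the better of the two groups at this position. With a carbonyl, compound 3 gives 88.4%; with a thiocarbonyl in that place, compound 4 gives 2%, so trifluoromethyl alone does not secure growth inhibition on this core. No measurement at hand bears on the reason for either result.

From the compounds shown here alone, whether an amine, a carboxylic acid or a methoxy group at this position would match or exceed compound 2 remains open. Also open, going by these compounds, is how sulfamoyl behaves on the same core when the thiocarbonyl is replaced by a carbonyl.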